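The compounds below may be only part of what the source reports. "The series", "measured", "known", "first", "only" and "open" are said of these compounds alone.

Working notes on the series. In a functional assay on MCF7 cells (Homo sapiens) for inhibition, read by MTT assay, with a stated time of 48 h, tested at 10 uM (on this read-out lower numbers stand for less inhibition of growth and higher numbers for more inhibition of growth at the one concentration tested), compound 1 (`Cc1cc(=O)c2c(O)c(CN(C)CC(=O)O)c(O)c([C@H]3CCN(C)C[C@H]3O)c2o1`) gives 27%, compound 2 (`CCOC(=O)N1CCN(Cc2c(O)c([C@H]3CCN(C)C[C@H]3O)c3oc(C)cc(=O)c3c2O)CC1`) gives 31% and compound 3 (`Cc1cc(=O)c2c(O)c(CN(C(C)C)C(C)C)c(O)c([C@H]3CCN(C)C[C@H]3O)c2o1`) gives 33%. All three share the core and differ only in the amino group on a saturated chain carbon bound to an aromatic carbon. Compound 3 is not separated from either neighbour: the measured steps are a number 2 percentage points higher from compound 2 to compound 3 (within the scatter) and a number 6 percentage points higher from compound 1 to compound 3 (within the scatter), and the remaining pair shows a number 4 percentage points higher from compound 1 to compound 2 (within the scatter).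

Compound 4 (`Cc1cc(=O)c2c(O)c(CN3CCCC3C(=O)O)c(O)c([C@H]3CCN(C)C[C@H]3O)c2o1`) is the next one to read. It carries 2-carboxypyrrolidin-1-yl in place of diisopropylamino at that same place: 2-carboxypyrrolidin-1-yl in place of diisopropylamino on a saturated chain carbon bound to an aromatic carbon. The most relevant measured comparison is with compound 1, which also carries a carboxy group in its amino substituent and which gives a number 6 percentage points higher from compound 1 to compound 3 (within the scatter). Read backwards, that step suggests a slightly lower number for compound 4, but no exchange of amino group so far has moved the read-out beyond the scatter. The expected change in this assay is therefore small and in the lower direction, estimated as a number 5 percentage points lower from compound 3 to compound 4 (within the scatter). For compound 4 the estimated value is 28%, with an expected range of 18% to 38%.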

Compound 4, percent growth inhibition at one concentration: 21%
Beside the measured number, compound 4's estimate is 7 percentage points above it; measured number inside the range.
By their numbers in this assay, from the lowest: compounds 4, 1, 2 and 3 (each within the scatter of the next, the first and the last beyond it).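

Exchanging the amino group on a saturated chain carbon bound to an aromatic carbon can move the read-out in this assay beyond the scatter: the series now holds a number 12 percentage points lower from compound 3 to compound 4 (beyond the scatter), its first step of that kind. The separation is limited, since a number 10 percentage points lower from compound 2 to compound 4 (within the scatter) and a number 6 percentage points lower from compound 1 to compound 4 (within the scatter) both remain within the scatter, and of the two compounds with a carboxy group in the amino substituent, only compound 4 is separated from compound 3, while compound 1 goes against any general link between that group and a lower number. No measured evidence bears on the cause of the step.

With 2-carboxypyrrolidin-1-yl, the five-membered ring and the carboxylic acid enter together, so the compounds shown do not tell their contributions apart; a plain pyrrolidin-1-yl group or the ethyl ester of 2-carboxypyrrolidin-1-yl would bear directly on that question. All the numbers also come from a single concentration, which leaves open whether the separation between compound 3 and compound 4 would hold across a concentration range.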